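Aryl exchange on compound 1: notes toward compound 4

The compounds below may be only part of what the source reports. "The series", "measured", "known", "first", "only" and "open" are said of these compounds alone.

Compound 1 `O=C(O)CCc1ccc(OCc2nc(-c3ccccc3Cl)no2)cc1` gives 1200 nM in a functional assay on CHO cells for agonist activity at Free fatty acid receptor 1 (Homo sapiens), read by FLIPR and calcium flux, in the presence of a further agent that is not named here; a lower number here means that less compound is needed, a higher number that more compound is needed for the effect.
Compound 2 `CC(Oc1ccc(CCC(=O)O)cc1)c1nc(-c2ccccc2)no1` gives 2390 nM in this assay.
Compound 3 `O=C(O)CCc1ccc(OCc2coc(-c3ccccc3)n2)cc1` gives 700 nM in this assay.

Compound 1 holds the second highest of the three numbers. Compound 3 is nearest and compound 2 furthest, yet both differences stay within the scatter, so the three compounds cannot be told apart on these numbers.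

Compound 4 `Cc1cc(-c2noc(COc3ccc(CCC(=O)O)cc3)n2)ccc1F` differs from compound 1 by 4-fluoro-3-methylphenyl in place of 2-chlorophenyl on an aromatic carbon. Within the data shown here, no pair of measured compounds shows this exchange, so its effect is unknown. In this assay no step beyond the scatter is expected, in either direction. Compound 4 is estimated at 1000 nM, with a range from 300 nM to 3500 nM. The expected step is a 1.2-fold lower number from compound 1 to compound 4 (0.08 log units; within the scatter).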

Compound 4, half-maximal effective concentration: 2120 nM
Compound 4: the middle estimate sits 2.1-fold (0.33 log units) below what was measured, and the stated range covers the measured number.
By their numbers in this assay, from the lowest: compounds 3, 1, 4 and 2 (each within the scatter of the next, the first and the last beyond it).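

In this assay, placing 4-fluoro-3-methylphenyl instead of 2-chlorophenyl on the aromatic carbon between two ring nitrogen atoms gives a 1.8-fold higher number from compound 1 to compound 4 (0.25 log units; within the scatter), the first step read at this position. This position therefore carries either substituted phenyl group with no change beyond the scatter, although the two groups share no substituent. No measurement at hand bears on a cause for this result.

Still open, on these data alone, is whether a cyclohexyl or pyridyl group at this position would move the number beyond the scatter. The separate contributions of the fluorine and the methyl also remain unresolved.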